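The source may hold more compounds than are shown below. What is called first, only, known or untested is meant among the compounds shown, and "the series" means these compounds.

Three analogues sharing one core have been tested in a functional assay on SR cells (Homo sapiens) for cytotoxicity, read by sulforhodamine B assay, with a stated time of 48 h, tested at 100 nM; a higher number here means a weaker effect of the compound at the concentration tested, a lower number a stronger effect. Compound 1, `COc1cc(C)cc(-c2c(-c3ccnc(-c4ccc(C(C)=O)cc4)c3)cnn2CC#N)c1`, gives 77% in this assay. Compound 2, `Cc1cc(O)cc(-c2nn(CC#N)cc2-c2ccnc(-c3ccc(Oc4ccccc4)cc3)c2)c1`, gives 96%. Compound 3, `COc1cc(C)cc(-c2nn(CC#N)cc2-c2ccnc(-c3ccc(N(C)C)cc3)c2)c1`, gives 26%, the lowest of the three numbers: its nearest neighbour is compound 1, whose number stands higher by a margin beyond the usual scatter, and compound 2 stands further away still, also beyond the scatter. Compound 3 is therefore the strongest of the three at the tested concentration.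

The next compound, compound 4, is `Cc1cc(O)cc(-c2nn(CC#N)cc2-c2ccnc(-c3ccc(N(C)C)cc3)c2)c1`. It differs from compound 3 in one place only: hydrogen in place of methyl on an oxygen on an aromatic ring. The methoxy group becomes a hydroxy group, so the 3-methoxy-5-methylphenyl ring of compound 3 becomes a 3-hydroxy-5-methylphenyl ring in compound 4.

Going by the values given here, no pair of measured compounds isolates this change. Compound 2 carries the same hydroxy ring and gives a high number, but it also differs from compound 3 elsewhere, so its value cannot be assigned to the hydroxy alone. Compound 4 is accordingly expected to lie above compound 3, with a step of a number 24 percentage points higher from compound 3 to compound 4 (beyond the scatter), though this expectation is loose. The estimate for compound 4 in this assay is 50%, within a range from 20% to 85%.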

Compound 4, a percentage reported as activity, at one concentration (the size of the read-out at that concentration, not a potency): 74%
Beside the measured number, compound 4's estimate is 24 percentage points below it; the measured number falls inside the stated range.
By their numbers in this assay, from the lowest: compound 3; then compounds 4 and 1 (each within the scatter of the next); then compound 2.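

Going by these compounds alone, the pair of compound 3 and compound 4 isolates the change on the oxygen for the first time: in this assay, with the dimethylamino group held in place, hydrogen in place of methyl gives a number 48 percentage points higher from compound 3 to compound 4 (beyond the scatter), so at the tested concentration the methoxy compound has the stronger effect of the two. Holding the 3-hydroxy-5-methylphenyl ring constant, the other pair shows that the far end of the molecule also counts, as dimethylamino in place of phenoxy gives a number 22 percentage points lower from compound 2 to compound 4 (beyond the scatter), a modest step in the direction of a stronger effect. The data show the size of these steps but give no explanation for either of them.

The compounds shown leave open whether a longer chain on this oxygen, such as an ethyl or a propyl group, would preserve the effect seen with methyl, or whether an amine or a fluorine in place of the oxygen group would do so. They also leave open how the change from methoxy to hydroxy behaves when the dimethylamino group is replaced by phenoxy or acetyl, since it has been isolated only with dimethylamino present.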